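Swapping Methoxy for Trifluoromethyl on a Shared Core

The source may report more compounds than this note shows. Statements on the series, on what has been measured and on what is new or still open speak of the compounds shown alone.

Compound 1 `COc1cc(-c2ccnc3cc(-c4ccc(C(C)(C)C)cc4)nn23)cc(OC)c1OC` gives > 10000 nM in a functional assay on HCT-116 cells (Homo sapiens) for inhibition, read by CCK-8 assay, with a stated time of 48 h; a lower number here means a stronger inhibitor, a higher number a weaker inhibitor; this is a limit of the assay, not a number.
Compound 2 `COc1cc(-c2ccnc3cc(-c4ccc5cnn(C)c5c4)nn23)cc(OC)c1OC` gives 2440 nM in this assay.
Compound 3 `COc1ccc(-c2cc3nccc(-c4cc(OC)c(OC)c(OC)c4)n3n2)cc1` gives 404 nM in this assay.

Compound 3 stands lowest of the two numbers shown; its nearest neighbour is compound 2, with a 6.0-fold lower number from compound 2 to compound 3 (0.78 log units; beyond the scatter). Compound 4 `COc1cc(-c2ccnc3cc(-c4ccc(C(F)(F)F)cc4)nn23)cc(OC)c1OC` has not yet been measured. It differs from compound 3 in one place: trifluoromethyl in place of methoxy on an aromatic carbon.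

For the measured compounds named here, two measured steps bear on this position. The first is an at least 24-fold lower number from compound 1 to compound 3 (1.39 log units; beyond the scatter), the step from a bulky carbon-only group to methoxy, which is large. The second is an at least 4.0-fold lower number from compound 1 to compound 2 (0.61 log units; beyond the scatter), which is at least modest. Compound 4 moves back away from methoxy, toward a group with no hydrogen-bond acceptor, as in compound 1. A step toward a higher number, beyond the scatter, is therefore expected, though trifluoromethyl is not tert-butyl and the full loss seen in compound 1 need not return.

The expected step is a 7.4-fold higher number from compound 3 to compound 4 (0.87 log units; beyond the scatter). Compound 4 is estimated to give about 3000 nM in this assay, with a range from 700 nM to 12000 nM.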

Compound 4, half-maximal inhibitory concentration: 1860 nM
Compound 4: middle estimate off by 1.6-fold (0.21 log units), on the high side, and the stated range covers the measured number.
By their numbers in this assay, from the lowest: compound 3; then compounds 4 and 2 (each within the scatter of the next). At a limit, above all of these: compound 1.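

With trifluoromethyl in place of methoxy on the phenyl ring, this assay shows a 4.6-fold higher number from compound 3 to compound 4 (0.66 log units; beyond the scatter), so this change costs activity but leaves a measurable number. Against tert-butyl at the same place, trifluoromethyl gives an at least 5.3-fold lower number from compound 1 to compound 4 (0.73 log units; beyond the scatter), and compound 1 stands at a limit, so this step is only a bound: the limit of > 10000 nM in this assay, at which 1 of the 4 values shown sits.

Replacing the whole group gives a 1.3-fold lower number from compound 2 to compound 4 (0.12 log units; within the scatter), so 4-(trifluoromethyl)phenyl and 1-methyl-1H-indazol-6-yl cannot be told apart here.

The compounds shown do not tell why methoxy gives the lowest number of the group. They also leave open how a hydroxyl group, a dimethylamino group or a single chlorine atom would compare at this place.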